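Swapping Allyl for Hydroxy on the Amide Nitrogen

The source may hold more compounds than are shown below. What is called first, only, known or untested is meant among the compounds shown, and "the series" means these compounds.

Compound 3 `C=CCN(Cc1cccs1)C(=O)COc1ccc(C)cc1` and its two close relatives share one core and differ only in the group on the amide-type nitrogen. In an assay on HEK293 cells for agonist activity at transient receptor potential cation channel subfamily M member 8 (Homo sapiens), read by fluorescence and calcium flux, with a stated time of 15 min (a higher number here means that more compound is needed for the effect, a lower number that less compound is needed), compound 3 gives 20 nM. Compound 1 `CON(Cc1cccs1)C(=O)COc1ccc(C)cc1`, carrying methoxy at that position, gives 10 nM, and compound 2 `CCCN(Cc1cccs1)C(=O)COc1ccc(C)cc1`, carrying propyl, gives 40 nM. Among these three numbers compound 3 stands second highest; the steps of a 2.0-fold higher number from compound 1 to compound 3 (0.30 log units; within the scatter) and a 2.0-fold lower number from compound 2 to compound 3 (0.30 log units; within the scatter) both lie within the scatter, while a 4.0-fold higher number from compound 1 to compound 2 (0.60 log units; beyond the scatter) is the only step beyond it. Compound 4 `Cc1ccc(OCC(=O)N(O)Cc2cccs2)cc1` has not yet been measured. The change is hydroxy in place of allyl on an amide-type nitrogen. Within the data shown here, no measured step places a hydroxy on this nitrogen, so the closest guide is a 2.0-fold higher number from compound 1 to compound 3 (0.30 log units; within the scatter), where a small oxygen-bearing group gave way to allyl; read in reverse it hints that returning to a small oxygen group yields a somewhat lower number, still within the scatter. A small step, a 1.3-fold lower number from compound 3 to compound 4 (0.12 log units; within the scatter), is therefore expected in this assay. Compound 4 is thus estimated at 15 nM, with a range from 4 nM to 60 nM.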

Compound 4, half-maximal effective concentration: 8000 nM
The estimate for compound 4 lay 530-fold (2.73 log units) below the measured number, outside the stated range (above it).
By their numbers in this assay, from the lowest: compounds 1, 3 and 2 (each within the scatter of the next, the first and the last beyond it); then compound 4.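

On this amide-type nitrogen, hydroxy behaves quite differently from the groups seen before: in this assay the change gives a 400-fold higher number from compound 3 to compound 4 (2.60 log units; beyond the scatter) and a 200-fold higher number from compound 2 to compound 4 (2.30 log units; beyond the scatter), both far larger than any step among methoxy, allyl and propyl. The clearest comparison is an 800-fold higher number from compound 1 to compound 4 (2.90 log units; beyond the scatter), since compound 1 has an oxygen at this same position and differs only by the methyl on that oxygen, so the oxygen alone does not bring the large rise; the change from methyl to hydrogen on it does. Nothing available explains why this small change has so large an effect.

The compounds shown leave open whether ethoxy or a longer chain on that oxygen would stay close to methoxy. They also leave open whether an amino group on this nitrogen would follow methoxy or hydroxy.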